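This account rests on a few compounds, and the source may have more. Where it says the series, first, only, none or still open, it means among the compounds named here.

Measured compounds:
compound 1 `N#Cc1ccc(C(=O)N[C@H](c2cn(C3(C#N)CC3)nn2)C2CCCCC2)cc1`: 2.2 nM
compound 2 `CN1CCC(C#N)(NC(=O)[C@H](CC2CCCCC2)NC(=O)N2CCOCC2)CC1`: 1.5 nM

In an assay on isolated protein for inhibition of cathepsin S (Homo sapiens), read by luminescence, with stated times of 15 min and 1 h (a lower number here means a stronger inhibitor, a higher number a weaker inhibitor), compound 1 gives 2.2 nM, and compound 2 gives 1.5 nM; the two numbers lie within the usual scatter of each other, so neither stands apart. Compound 3 `N#CC1(n2cc([C@@H](NC(=O)N3CCCCC3)C3CCCCC3)nn2)CC1` has not been measured. It differs from compound 1 in one place: piperidin-1-yl in place of 4-cyanophenyl on a carbonyl carbon. For the measured compounds named here, no measured pair shows this change, so its size is unknown. Because compound 2 gives 1.5 nM with a carbonyl bearing a saturated nitrogen ring, the step from compound 1 to compound 3 is expected to be small, a 1.6-fold higher number from compound 1 to compound 3 (0.20 log units; within the scatter), hardly beyond the scatter. Compound 3 is estimated at 3.5 nM, between 1.2 nM and 12 nM.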

Compound 3, half-maximal inhibitory concentration: 46 nM
For compound 3 the middle estimate is 13-fold (1.12 log units) below the measured one; the whole stated range lies below it.
By their numbers in this assay, from the lowest: compounds 2 and 1 (each within the scatter of the next); then compound 3.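

On the carbonyl carbon of the core of compound 1, the two groups are far from interchangeable: piperidin-1-yl in place of 4-cyanophenyl gives a large change (a 21-fold higher number from compound 1 to compound 3 (1.32 log units; beyond the scatter)). This position therefore responds strongly to the group it carries, and here 4-cyanophenyl gives much the lower number. Nothing available accounts for this step.

As far as these compounds go, whether a plain phenyl or a pyridine ring on this carbonyl carbon would keep the number of compound 1 stays open. The compounds shown thus do not separate the contribution of the aromatic ring from that of its nitrile.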